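Replacing one aromatic group on a shared core

The source may report more compounds than this note shows. Statements on the series, on what has been measured and on what is new or still open speak of the compounds shown alone.

Measured in an ADME assay on K562 cells (Homo sapiens) for antiproliferative activity; on this read-out higher numbers stand for weaker inhibition and lower numbers for stronger inhibition:
Compound 1 `COc1ccc2nccc(CC[C@H]3OC[C@H](NCc4cc5c(cn4)OCCO5)CO3)c2c1`: 40000 nM
Compound 2 `COc1ccc2nccc(CC[C@H]3OC[C@H](NCc4ccc5c(n4)NC(=O)CS5)CO3)c2c1`: 31000 nM
Compound 3 `COc1ccc2nccc(CC[C@H]3OC[C@H](NCc4ccc5c(c4)OCCO5)CO3)c2c1`: 7400 nM

Among these three, compound 3 has the lowest number, 7400 nM, and so the strongest inhibition, with both of its gaps to the others beyond the scatter. The next structure, compound 4 `COc1ccc2nccc(CC[C@H]3OC[C@H](NCc4ccc(Cl)cc4)CO3)c2c1`, has 4-chlorophenyl in place of 2,3-dihydro-1,4-benzodioxin-6-yl on a saturated chain carbon bound to an amine nitrogen.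

For the measured compounds named here, two measured steps bear on this most directly: a 5.4-fold lower number from compound 1 to compound 3 (0.73 log units; beyond the scatter), and a 4.2-fold lower number from compound 2 to compound 3 (0.62 log units; beyond the scatter). In both, the group that enters has a six-membered aromatic ring of carbon only, which compound 4 keeps. The third step, a 1.3-fold lower number from compound 1 to compound 2 (0.11 log units; within the scatter), says less about this change. Going by the values given here, no measured compound carries 4-chlorophenyl, so the evidence is indirect, and no step beyond the scatter is expected in this assay. The expected step is a 1.2-fold lower number from compound 3 to compound 4 (0.09 log units; within the scatter). For compound 4 the estimated value is 6000 nM, with an expected range from 2000 nM to 20000 nM.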

Compound 4, half-maximal inhibitory concentration: 12000 nM
Estimate against measurement, compound 4: 2.0-fold (0.30 log units) below; the range from low to high includes it.
By their numbers in this assay, from the lowest: compounds 3 and 4 (each within the scatter of the next); then compounds 2 and 1 (each within the scatter of the next).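

In this assay, 4-chlorophenyl has no non-aromatic ring and no hydrogen-bond acceptors, unlike 2,3-dihydro-1,4-benzodioxin-6-yl, yet the swap gives only a small change (a 1.6-fold higher number from compound 3 to compound 4 (0.21 log units; within the scatter)), so on this saturated chain carbon the read-out does not depend on keeping that second ring. Compound 4 also stands clear of the two compounds whose aromatic ring holds a hetero atom (a 2.6-fold lower number from compound 2 to compound 4 (0.41 log units; beyond the scatter) and a 3.3-fold lower number from compound 1 to compound 4 (0.52 log units; beyond the scatter)), so among these four, both compounds with a carbon-only aromatic ring have the lower numbers, and none goes against this. No measurement shown here explains these differences.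

From the compounds shown here alone, what a plain phenyl or a 4-methoxyphenyl would give remains open, so the part played by the chlorine cannot be told. Going by these compounds, whether the group must be aromatic at all also remains open, as a cyclohexyl group would test.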